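Ester Core, Amine for Nitro: Reading the Step Across

The source may report more compounds than this note shows. Statements on the series, on what has been measured and on what is new or still open speak of the compounds shown alone.

Two cores appear in this set. Compound 1 `COc1ccc(-n2ccnc2-c2cc(OC)c(OC)c(OC)c2)cc1[N+](=O)[O-]` and compound 2 `COc1ccc(-n2ccnc2-c2cc(OC)c(OC)c(OC)c2)cc1N` share one core, while compound 3 `COc1ccc(OC(=O)c2cc(OC)c(OC)c(OC)c2)cc1[N+](=O)[O-]` and the not yet measured compound 4 `COc1ccc(OC(=O)c2cc(OC)c(OC)c(OC)c2)cc1N` share another. How the core of compound 1 differs from the core of compound 3 is not broken down here.

In a functional assay on MDA-MB-468 cells (Homo sapiens) for antiproliferative activity, read by MTT assay, with a stated time of 72 h (a lower number here means a stronger inhibitor, a higher number a weaker inhibitor), compound 1 gives 100 nM. In this assay compound 2 gives 90 nM. The step of a 1.1-fold lower number from compound 1 to compound 2 (0.05 log units; within the scatter) belongs to the change (amino in place of nitro on an aromatic carbon), and the two values cannot be told apart. For compound 3 the result in this assay is a limit, > 100000 nM, not a number. That is the limit of > 100000 nM in this assay, at which 1 of the 3 values shown sits.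

Compound 4 stands to compound 3 as compound 2 stands to compound 1: the change is amino in place of nitro on an aromatic carbon, and the surroundings of the place are described in the same words in both cases, so it is the same change made on a second core.

Among the compounds with values here, only one measured instance of this change exists, the step of a 1.1-fold lower number from compound 1 to compound 2 (0.05 log units; within the scatter), and it lies within the scatter. On that alone, compound 4 is expected to move by about a number no higher from compound 3 to compound 4 (the limit leaves the size open) from compound 3, which is to say hardly at all. Compound 4 is therefore estimated at 100000 nM in this assay, with a range from 30000 nM to 300000 nM, and a limit rather than a number is the likelier report.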

Compound 4, half-maximal inhibitory concentration: > 100000 nM
Compound 4 gave a limit, no number; the forecaster's own chance of this, stated with the estimate: 80%; the middle value sits exactly at the limit.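

In this assay compound 4 gives > 100000 nM as its result, which is a limit and not a number. Compound 3 also stands at a limit, so no step can be read between compound 3 and compound 4. The compounds shown leave open whether amino in place of nitro shifts the activity at all on the core shared by compound 3 and compound 4.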